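Compound 3 and the loss of its methoxy groups

This account rests on a few compounds, and the source may have more. Where it says the series, first, only, none or still open, it means among the compounds named here.

Compound 1 `CCCCCCCCNC(=O)[C@@H]1CSC(c2cc(OC)c(OC)c(OC)c2)N1` gives 19600 nM
Compound 2 `CCCCCCCCCCNC(=O)[C@@H]1CSC(c2cc(OC)c(OC)c(OC)c2)N1` gives 2100 nM
Compound 3 `CCCCCCCCCCCCCCCCNC(=O)[C@@H]1CSC(c2cc(OC)c(OC)c(OC)c2)N1` gives 700 nM

In a functional assay on WM164 cells (Homo sapiens) for antiproliferative activity, read by sulforhodamine B assay, with a stated time of 48 h (on this read-out lower numbers stand for stronger inhibition and higher numbers for weaker inhibition), compound 3 holds the lowest of the three numbers, and its nearest neighbour is compound 2 (2100 nM). The next compound, compound 4 `CCCCCCCCCCCCCCCCNC(=O)[C@@H]1CSC(c2ccccc2)N1`, keeps the chain and the shared core of compound 3 but carries phenyl in place of 3,4,5-trimethoxyphenyl on a saturated ring carbon. The measured steps all lengthen the chain. These are a modest one (a 9.3-fold lower number from compound 1 to compound 2 (0.97 log units; beyond the scatter)), a large one (a 28-fold lower number from compound 1 to compound 3 (1.45 log units; beyond the scatter)) and another modest one (a 3.0-fold lower number from compound 2 to compound 3 (0.48 log units; beyond the scatter)). Among the measured compounds shown here, they bear on this change only indirectly, as no measured pair alters the 3,4,5-trimethoxyphenyl group, so the data give no firm direction. No step beyond the scatter is therefore expected in this assay, with a slightly higher number as the tentative guess. The expected change is small (a 1.4-fold higher number from compound 3 to compound 4 (0.15 log units; within the scatter)) and remains only an estimate. Compound 4 is estimated at 1000 nM (expected range 300 nM to 3300 nM).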

Compound 4, half-maximal inhibitory concentration: 700 nM
The estimate for compound 4 lay 1.4-fold (0.15 log units) above the measured number; the measured number falls inside the stated range.
By their numbers in this assay, from the lowest: compounds 3 and 4 (each within the scatter of the next); then compound 2; then compound 1.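

Within this assay the swap of 3,4,5-trimethoxyphenyl for phenyl on the saturated ring carbon gives no change at the digits printed from compound 3 to compound 4 (within the scatter) and is the first reading at this position, as every earlier step altered the chain. With the chain of compound 3 held fixed, all three methoxy groups and their hydrogen-bond acceptors can therefore go without a step beyond the scatter in this read-out. Nothing given here explains this result.

From the compounds shown here alone, whether phenyl and 3,4,5-trimethoxyphenyl would also match on the shorter chains of compound 1 and compound 2 remains open. So does whether a single methoxy group, an amine or a carboxylic acid on the phenyl ring would leave the number at this level.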